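A few compounds are considered here, and "the series" means these few. Any claim that something is new, unique, unknown or untested is made for them only; others in the source may bear on it.

In a functional assay on K562 cells (Homo sapiens) for antiproliferative activity, read by MTT assay, with a stated time of 72 h (a higher number here means a weaker inhibitor, a lower number a stronger inhibitor), compound 1 `COc1ccc(-c2c(C(=O)c3cc(OC)c(OC)c(OC)c3)sc3ccccc23)cc1` gives 1700 nM, compound 2 `COc1cc(C(=O)c2sc3ccccc3c2-c2ccc(SC)cc2)cc(OC)c1OC` gives 1800 nM and compound 3 `CCOc1ccc(-c2c(C(=O)c3cc(OC)c(OC)c(OC)c3)sc3ccccc23)cc1` gives 3100 nM. Compound 3 therefore stands within the scatter of both others, with a 1.8-fold higher number from compound 1 to compound 3 (0.26 log units; within the scatter) and a 1.7-fold higher number from compound 2 to compound 3 (0.24 log units; within the scatter). The next compound, compound 4 `COc1cc(C(=O)c2sc3ccccc3c2Nc2ccc(C)cc2)cc(OC)c1OC`, carries (4-methylphenyl)amino in place of 4-ethoxyphenyl on an aromatic carbon. The remaining measured step is a 1.1-fold higher number from compound 1 to compound 2 (0.02 log units; within the scatter). All three steps only exchange the alkoxy or methylsulfanyl group on the phenyl ring, and none tests an amino group entering at this place. They offer only weak guidance, so no step beyond the scatter is expected in this assay, with wide uncertainty. The expected step is a 1.8-fold lower number from compound 3 to compound 4 (0.26 log units; within the scatter). For compound 4 the estimate is 1700 nM, with an expected range of 250 nM to 8000 nM.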

Compound 4, half-maximal inhibitory concentration: 1600 nM
The estimate for compound 4 lay 1.1-fold (0.03 log units) above the measured number; the measured number falls inside the stated range.
By their numbers in this assay, from the lowest: compounds 4, 1, 2 and 3 (each within the scatter of the next).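

In this assay the swap at this aromatic carbon of the five-membered ring holds up against all three aryl compounds: a 1.9-fold lower number from compound 3 to compound 4 (0.29 log units; within the scatter) and a 1.1-fold lower number from compound 2 to compound 4 (0.05 log units; within the scatter) and a 1.1-fold lower number from compound 1 to compound 4 (0.03 log units; within the scatter). An amino link carrying a hydrogen-bond donor can thus replace the directly attached phenyl here with no step beyond the scatter, a larger change than the exchanges on the phenyl ring seen so far. Nothing available explains this result.

Open, going by these compounds, is whether the methyl on the amino-linked phenyl matters, for instance against a methoxy or ethoxy group there. Also open, on these data alone, is how an oxygen ether link or a methylated amine nitrogen would read at this carbon.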